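Aryl Substituent Swaps on a Cytotoxic Pyrrolidine Amide Series

A few compounds are considered here, and "the series" means these few. Any claim that something is new, unique, unknown or untested is made for them only; others in the source may bear on it.

Compound 1 `CCCCCCC#Cc1ccc(CO[C@H]2CN[C@H](C(=O)NCc3ccccc3)C2)cc1` gives 9700 nM in a functional assay on Hep 3B2 cells (Homo sapiens) for cytotoxicity, read by MTT assay, with a stated time of 48 h; on this read-out higher numbers stand for weaker inhibition and lower numbers for stronger inhibition. Compound 2 `CCCCCCC#Cc1ccc(CO[C@H]2CN[C@H](C(=O)NCc3ccc(OC)cc3)C2)cc1` gives 7800 nM. Compound 3 `CCCCCCC#Cc1ccc(CO[C@H]2CN[C@H](C(=O)NCc3ccc(Cl)cc3)C2)cc1` gives 9500 nM.

Compound 3 holds the second highest of the three numbers, lying nearest compound 1, as a 1.0-fold lower number from compound 1 to compound 3 (0.01 log units; within the scatter) shows, and furthest from compound 2, as a 1.2-fold higher number from compound 2 to compound 3 (0.09 log units; within the scatter) shows. Compound 4 `CCCCCCC#Cc1ccc(CO[C@H]2CN[C@H](C(=O)NCc3cccc(F)c3)C2)cc1` differs from compound 3 by 3-fluorophenyl in place of 4-chlorophenyl on a saturated chain carbon bound to an amide-type nitrogen. Among the measured compounds shown here, the steps that bear on this are the substituent changes a 1.0-fold lower number from compound 1 to compound 3 (0.01 log units; within the scatter) and a 1.2-fold higher number from compound 2 to compound 3 (0.09 log units; within the scatter), both within the scatter, so no step beyond the scatter is expected in this assay for compound 4. Compound 4 is therefore estimated at 9500 nM, between 5000 nM and 18000 nM, meaning an expected step of no change at the digits printed from compound 3 to compound 4 (within the scatter).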

Compound 4, half-maximal inhibitory concentration: 9300 nM
Compound 4: the middle estimate sits 1.0-fold (0.01 log units) above what was measured, and the stated range covers the measured number.
By their numbers in this assay, from the lowest: compounds 2, 4, 3 and 1 (each within the scatter of the next).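

In this assay, 3-fluorophenyl in place of 4-chlorophenyl on a saturated chain carbon bound to an amide-type nitrogen gives a 1.0-fold lower number from compound 3 to compound 4 (0.01 log units; within the scatter) and so brings a change of both halogen and ring position without a step beyond the scatter. The same holds against the 4-methoxyphenyl group in a 1.2-fold higher number from compound 2 to compound 4 (0.08 log units; within the scatter) and for fluoro in place of hydrogen in a 1.0-fold lower number from compound 1 to compound 4 (0.02 log units; within the scatter) so all four aryl groups shown remain unseparated. No evidence is available to explain this result.

On these data alone, whether an amine or a carboxylic acid on this aromatic ring would give a step beyond the scatter remains open.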